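The compounds below may be only part of what the source reports. "The series", "measured", "known", "first", "only" and "open" are said of these compounds alone.

Measured compounds:
compound 1, `COc1ccc([C@@H]2[C@H](Oc3ccccc3)C(=O)N2c2cc(OC)c(OC)c(OC)c2)cc1`: 35000 nM
compound 2, `COc1ccc([C@@H]2[C@H](Oc3ccccc3)C(=O)N2c2cc(OC)c(OC)c(OC)c2)cc1OC`: 26000 nM
compound 3, `COc1ccc([C@@H]2[C@H](Oc3ccccc3)C(=O)N2c2cc(OC)c(OC)c(OC)c2)cc1[N+](=O)[O-]`: 69000 nM

These three share one core and differ only on one aromatic ring. In a functional assay on MCF7 cells (Homo sapiens) for antiproliferative activity, read by MTT assay, with stated times of 24 h and 72 h (a lower number here means a stronger inhibitor, a higher number a weaker inhibitor), compound 1 gives 35000 nM, compound 2 gives 26000 nM and compound 3 gives 69000 nM. The step of a 1.3-fold higher number from compound 2 to compound 1 (0.13 log units; within the scatter) is one change, (hydrogen in place of methoxy on an aromatic carbon). The step of a 2.0-fold higher number from compound 1 to compound 3 (0.29 log units; within the scatter) is another, and the step of a 2.7-fold higher number from compound 2 to compound 3 (0.42 log units; beyond the scatter) is the only one beyond the scatter, described as nitro in place of methoxy on an aromatic carbon; this also tells how the core of compound 3 differs from that of compound 2.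

Compound 4, `COc1cc(N2C(=O)[C@@H](Oc3ccccc3)[C@H]2c2cccc([N+](=O)[O-])c2)cc(OC)c1OC`, is not yet measured. It differs from compound 3 by hydrogen in place of methoxy on an aromatic carbon. This is the same kind of change as that from compound 2 to compound 1, not the same: there the leaving methoxy sat ortho to a methoxy group and meta to a large group, here it sits ortho to a nitro group and para to a large group. The earlier step, a 1.3-fold higher number from compound 2 to compound 1 (0.13 log units; within the scatter), was within the scatter, so a small step is expected here as well, a 1.2-fold higher number from compound 3 to compound 4 (0.06 log units; within the scatter), resting on that earlier step. Compound 4 is therefore expected to give about 80000 nM, between 35000 nM and 180000 nM.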

Compound 4, half-maximal inhibitory concentration: 30000 nM
Estimate against measurement, compound 4: 2.7-fold (0.43 log units) above; measured number outside the range, below it.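

Replacing the methoxy of the 4-methoxy-3-nitrophenyl group with hydrogen gives a 2.3-fold lower number from compound 3 to compound 4 (0.36 log units; beyond the scatter), so in this assay the same swap does not behave alike on the two cores: the same change on two cores in this assay, a 1.3-fold higher number (0.13 log units; within the scatter) from compound 2 to compound 1 and a 2.3-fold lower number (0.36 log units; beyond the scatter) from compound 3 to compound 4, 3.1-fold (0.49 log units) apart, beyond the scatter of two such steps

Compound 4 also lies within the scatter of the two compounds that carry no nitro group, with a 1.2-fold higher number from compound 2 to compound 4 (0.06 log units; within the scatter) and a 1.2-fold lower number from compound 1 to compound 4 (0.07 log units; within the scatter). The result therefore warns against carrying the size of this step from one core to another in this series, but it rests on just two pairs and does not show why the steps differ or how the swap would behave on any other core.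

The compounds shown leave open whether the gap is tied to the nitro group or would also appear with a nitrile or an amine in its place. They also leave open what a hydroxyl or an ethoxy group would give in place of the methoxy.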